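The source may hold more compounds than are shown below. What is called first, only, known or untested is meant among the compounds shown, and "the series" means these compounds.

Going by the values given here, compound 1 `COc1ccc(C(=O)Nc2cccc3c(=O)cc(C(=O)O)oc23)cc1` gives 2160 nM in an assay on CHO cells for agonist activity at G protein-coupled receptor GPR35 (Rattus norvegicus), read by a beta-galactosidase reporter and beta-arrestin recruitment, with a stated time of 90 min (a lower number here means that less compound is needed, a higher number that more compound is needed for the effect), the lowest of the two numbers known; compound 2 `COC(=O)CC(=O)Nc1cccc2c(=O)cc(C(=O)O)oc12` gives 6650 nM, and the only measured step, a 3.1-fold higher number from compound 1 to compound 2 (0.49 log units; beyond the scatter), replaces the 4-methoxyphenyl on the carbonyl carbon with (methoxycarbonyl)methyl. Compound 3 `CCCOc1ccc(C(=O)Nc2cccc3c(=O)cc(C(=O)O)oc23)cc1` differs from compound 1 by ethyl in place of hydrogen on a saturated chain carbon bound to an oxygen on an aromatic ring. Among the compounds with values here, no measured step touches this saturated chain carbon bound to an oxygen on an aromatic ring, so the earlier step offers little guidance; the change is expected to stay within the scatter, a 1.2-fold lower number from compound 1 to compound 3 (0.08 log units; within the scatter). Compound 3 is therefore estimated at 1800 nM, between 600 nM and 5500 nM.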

Compound 3, half-maximal effective concentration: 3610 nM
For compound 3 the middle estimate is 2.0-fold (0.30 log units) below the measured one; measured number inside the range.
By their numbers in this assay, from the lowest: compounds 1, 3 and 2 (each within the scatter of the next, the first and the last beyond it).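

With propoxy in place of methoxy, this assay shows a 1.7-fold higher number from compound 1 to compound 3 (0.22 log units; within the scatter), so this first measured step at the saturated chain carbon bound to an oxygen on an aromatic ring separates compound 3 from compound 1 by no more than the scatter. Adding ethyl at this place therefore leaves the two compounds indistinguishable in this read-out. No supporting measurement bears on this result. Going by these compounds, whether a longer chain such as butoxy would also stay within the scatter remains open. So does the outcome of placing an amine or a carboxylic acid at the end of this chain.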